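This account rests on a few compounds, and the source may have more. Where it says the series, first, only, none or still open, it means among the compounds named here.

Three compounds share one core and differ only in the group on one aromatic carbon. Compound 1 `COc1ccc(C(=O)c2c(N)sc3c2CCC3)c2ccccc12` carries methoxy there; in an assay on isolated protein with adenosine receptor A1 (Homo sapiens) as the target, tested at 10 uM (on this read-out higher numbers stand for more inhibition at the one concentration tested (going by the name of the read-out) and lower numbers for less inhibition), compound 1 gives 19%. Compound 2 `Nc1sc2c(c1C(=O)c1ccc(Cl)c3ccccc13)CCC2` carries chloro, and in this assay compound 2 gives 0%. Compound 3 `Nc1sc2c(c1C(=O)c1ccc(Br)c3ccccc13)CCC2` carries bromo, and in this assay compound 3 gives 0%.

The steps between them show a number 19 percentage points lower from compound 1 to compound 2 (beyond the scatter) and a number 19 percentage points lower from compound 1 to compound 3 (beyond the scatter), both beyond the scatter, while no change at the digits printed from compound 2 to compound 3 (within the scatter). Compound 3 therefore stands level with compound 2, the two together being the lowest of the three numbers, and furthest from compound 1.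

Compound 4 `Nc1sc2c(c1C(=O)c1ccc(I)c3ccccc13)CCC2` differs from compound 3 by iodo in place of bromo on an aromatic carbon. Within the data shown here, the one measured step that bears on this change is the earlier exchange of one halogen for another, no change at the digits printed from compound 2 to compound 3 (within the scatter), which lay within the scatter. A third halogen in the same place is therefore expected to give a step of about no change at the digits printed from compound 3 to compound 4 (within the scatter), no change beyond the scatter. The estimate for compound 4 in this assay is 0%, with a range from 0% to 10%.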

Compound 4, a percentage reported as inhibition, at one concentration (the size of the read-out at that concentration, not a potency): 3.3%
Compound 4: the middle estimate sits 3.3 percentage points below what was measured; the measured number falls inside the stated range.
By their numbers in this assay, from the lowest: compounds 2, 3 and 4 (each within the scatter of the next); then compound 1.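

In this assay the exchange of bromo for iodo gives a number 3.3 percentage points higher from compound 3 to compound 4 (within the scatter) and the exchange of chloro for iodo gives a number 3.3 percentage points higher from compound 2 to compound 4 (within the scatter), so at this place, para to a large group, chloro, bromo and iodo cannot be told apart on this read-out. The gap to methoxy, seen earlier for chloro and bromo, now extends to a third halogen, with a number 15.7 percentage points lower from compound 1 to compound 4 (beyond the scatter), although compound 1 itself gives just 19% in this assay. Nothing at hand explains why methoxy stands apart from the three halogens.

The compounds shown hold only methoxy and halogens at this aromatic carbon, so it stays open whether an amine, a carboxylic acid or a longer ether chain such as ethoxy would give a number above that of compound 1 or one level with the halogens. Going by these compounds, it also stays open whether the gap between methoxy and the halogens would hold at other concentrations, since a single concentration gives no potency.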